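This account rests on a few compounds, and the source may have more. Where it says the series, first, only, none or still open, it means among the compounds named here.

Compound 1, `O=C(/C=C/c1ccccc1)NNC(=O)c1ccccc1O`: 20100 nM
Compound 2, `COc1ccc(NC(=O)COC(=O)/C=C/c2cc(OC)c(OCc3ccc(Cl)c(Cl)c3)c(OC)c2)cc1`: > 200000 nM
Compound 3, `COc1ccc(NC(=O)COC(=O)/C=C/c2cc(OC)c(OCc3ccccc3)c(OC)c2)cc1`: > 200000 nM

Of the compounds shown here, three have been tested in a functional assay on LS174T cells (Homo sapiens) for cytotoxicity, read by MTT assay, with a stated time of 72 h; on this read-out higher numbers stand for weaker inhibition and lower numbers for stronger inhibition. Compound 1 is the only one of them that gives a number, 20100 nM. For compound 2 the reported value > 200000 nM is a limit of the assay and not a number. For compound 3 the reported value > 200000 nM is likewise a limit. Among the measured compounds shown here, because both ends sit at the limit of > 200000 nM in this assay, at which 2 of the 3 values shown sit, the only single-point change among the measured compounds, a step that the two limits leave unreadable from compound 2 to compound 3, cannot be read: exchanging the 3,4-dichlorophenyl for a phenyl left compound 3 at the same limit as compound 2. Compound 2 therefore stands at the edge of what this assay can report, with nothing to place it above or below compound 3.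

Compound 4, `COc1cc(/C=C/C(=O)OCC(=O)Nc2ccc(Cl)cc2)cc(OC)c1OCc1ccc(Cl)c(Cl)c1`, keeps the whole of compound 2 except at the far end of the molecule: chloro in place of methoxy on an aromatic carbon. For the measured compounds named here, no measured step bears on this kind of exchange, and the one step that is known gives no size at all. With compound 2 already at its limit, a change to a number cannot be predicted from what is shown, and the expected outcome is that compound 4 again reaches the limit, so that no step beyond the scatter is expected in this assay.

The estimate for compound 4 is therefore 200000 nM, within 60000 nM to 600000 nM, meaning an expected step of a number no higher from compound 2 to compound 4 (the limit leaves the size open).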

Compound 4, half-maximal inhibitory concentration: 72400 nM
For compound 4 the middle estimate is 2.8-fold (0.44 log units) above the measured one, and the stated range covers the measured number.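

In this assay, among the compounds shown here, the far end of the molecule is the first place where a single exchange gives a readable result: chloro in place of methoxy on an aromatic carbon, para to a large group, gives an at least 2.7-fold lower number from compound 2 to compound 4 (0.44 log units; beyond the scatter). For compound 2 the value > 200000 nM is a limit and not a number. Compound 4 gives 72400 nM, so this series can produce a measurable number in this assay, and a change at this position alone is enough to bring it there, whereas the exchange at the other end of the molecule, between the 3,4-dichlorophenyl and the phenyl, could not be read.

As far as these compounds go, whether the gain belongs to chloro in particular or would also come with another group at this position, such as fluoro, an amine or a carboxylic acid, stays open. Also open, from the compounds shown here alone, is whether phenyl in place of 3,4-dichlorophenyl, unreadable between compound 2 and compound 3, would show a measurable step if the chloro of compound 4 were kept.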